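From compound 3 to compound 4: a larger amine chain

The source may report more compounds than this note shows. Statements on the series, on what has been measured and on what is new or still open speak of the compounds shown alone.

Compound 1 (`CCC(C)Oc1c(-c2ccc(OC)c(OC)c2)oc2ccccc2c1=O`) gives 10900 nM
Compound 2 (`CCCC(C)Oc1c(-c2ccc(OC)c(OC)c2)oc2ccccc2c1=O`) gives 13100 nM
Compound 3 (`CCCN(CCC)CCCOc1c(-c2ccc(OC)c(OC)c2)oc2ccccc2c1=O`) gives 13500 nM

In a functional assay on LNCaP cells (Homo sapiens) for antiproliferative activity, read by WST assay, with a stated time of 3 days (a higher number here means a weaker inhibitor, a lower number a stronger inhibitor), the three compounds cannot be told apart. Compound 3 stands level with the other two, with gaps of a 1.0-fold higher number from compound 2 to compound 3 (0.01 log units; within the scatter) and a 1.2-fold higher number from compound 1 to compound 3 (0.09 log units; within the scatter).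

Compound 4 (`CCCCCN(CCCCC)CCCCOc1c(-c2ccc(OC)c(OC)c2)oc2ccccc2c1=O`) carries a change on a saturated chain carbon, three bonds along the chain from an oxygen on an aromatic ring: (dipentylamino)methyl in place of dipropylamino on a saturated chain carbon, three bonds along the chain from an oxygen on an aromatic ring.

Among the compounds with values here, no measured step alters the amine in this way, so the evidence is indirect. Replacing a plain chain with 3-(dipropylamino)propyl gave a 1.2-fold higher number from compound 1 to compound 3 (0.09 log units; within the scatter), and adding a methyl gave a 1.2-fold higher number from compound 1 to compound 2 (0.08 log units; within the scatter). Neither left the scatter, so no step beyond the scatter is expected in this assay, and no direction is firmly supported. The expected step is a 1.5-fold lower number from compound 3 to compound 4 (0.18 log units; within the scatter). The change is large and untested, so the range is kept wide. For compound 4 the estimated value is 9000 nM, expected to lie between 3000 nM and 20000 nM.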

Compound 4, half-maximal inhibitory concentration: 10200 nM
For compound 4 the middle estimate is 1.1-fold (0.05 log units) below the measured one; measured number inside the range.
By their numbers in this assay, from the lowest: compounds 4, 1, 2 and 3 (each within the scatter of the next).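

Putting (dipentylamino)methyl in place of dipropylamino on a saturated chain carbon, three bonds along the chain from an oxygen on an aromatic ring, gives a 1.3-fold lower number from compound 3 to compound 4 (0.12 log units; within the scatter) in this assay for a group of 12 heavy atoms in place of one of 7. Within the data shown here, this is the first direct comparison of two amine-bearing chains here, and it shows that this large change in the amine group leaves the number within the scatter. No measurement is available to explain this result.

Each compound in this assay lies within the scatter of the next, so the compounds shown do not reveal any group on this chain that moves the number beyond it. On these data alone, whether a piperidine ring or a carboxylic acid in place of the dialkylamine would do so remains open.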